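The compounds below may be only part of what the source reports. "The series", "measured", "known", "first", "only" and "open" are said of these compounds alone.

Series notes. Two compounds of the shared core carry a measured number in an assay on CHO-K1 cells for antagonist activity at transient receptor potential cation channel subfamily V member 1 (Homo sapiens), read by FLIPR; on this read-out lower numbers stand for stronger inhibition and higher numbers for weaker inhibition. Compound 1 `CC(C)CCSc1nc(C(F)(F)F)ccc1CNC(=O)C(C)c1ccc(NS(C)(=O)=O)c(F)c1` gives 0.7 nM. Compound 2 `CC1CCC(Sc2nc(C(F)(F)F)ccc2CNC(=O)C(C)c2ccc(NS(C)(=O)=O)c(F)c2)CC1` gives 0.5 nM, the lowest of the two numbers, though the gap to compound 1 is within the scatter, so no order between them is read. Among the compounds with values here, the only measured step, a 1.4-fold lower number from compound 1 to compound 2 (0.15 log units; within the scatter), swaps a chain for a saturated ring on the sulfur and leaves the read-out essentially unchanged.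

Compound 3 `CC(C(=O)NCc1ccc(C(F)(F)F)nc1SCc1ccc(Cl)cc1)c1ccc(NS(C)(=O)=O)c(F)c1` is not yet measured. The change from compound 2 is 4-chlorobenzyl in place of 4-methylcyclohexyl on a sulfur. Within the data shown here, the one measured step bears on it only loosely: it shows that the group on the sulfur can be altered between an isopentyl and a 4-methylcyclohexyl without a shift beyond the scatter, but no compound yet carries an aromatic ring at that sulfur, so the effect of a 4-chlorobenzyl there is not anchored by any data. A step of no more than the scatter is therefore expected, with the range widened for the untested aromatic group, giving a 2.0-fold higher number from compound 2 to compound 3 (0.30 log units; within the scatter) as the estimate. Compound 3 is estimated at 1 nM, between 0.3 nM and 4 nM.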

Compound 3, inhibition constant: 8.7 nM
Compound 3: the middle estimate sits 8.7-fold (0.94 log units) below what was measured; the whole stated range lies below it.
By their numbers in this assay, from the lowest: compounds 2 and 1 (each within the scatter of the next); then compound 3.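

In this assay the sulfur position proves less forgiving than the first two compounds suggested: 4-chlorobenzyl in place of 4-methylcyclohexyl gives a 17-fold higher number from compound 2 to compound 3 (1.24 log units; beyond the scatter), and the same group set against the isopentyl chain gives a 12-fold higher number from compound 1 to compound 3 (1.09 log units; beyond the scatter). The two saturated groups, one a chain and one a ring, stay within the scatter of each other, while the one aromatic group shown stands apart from both, a contrast that so far rests on a single compound. Nothing measured here accounts for the size of this step.

The entering group brings an aromatic ring and a chlorine in one change, so the compounds shown leave open which of the two goes with the step, and a plain benzyl or a 4-fluorobenzyl on the sulfur would bear on that question. Also open, going by these compounds, is how the position responds to other kinds of group, such as a longer chain, a phenyl ring bound directly to the sulfur, or a chain ending in an amine or a carboxylic acid.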